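Fluoro to methoxy swap on the pyrrole-linked aryl ring

The source may report more compounds than this note shows. Statements on the series, on what has been measured and on what is new or still open speak of the compounds shown alone.

Measured so far in a functional assay on MDA-MB-231 cells (Homo sapiens) for cytotoxicity, read by MTT assay, with a stated time of 72 h; a higher number here means a weaker inhibitor, a lower number a stronger inhibitor:
compound 1 `Cc1ccc(-c2ccc(C)n2-c2ccc(-c3nc4ccc(F)cc4s3)cc2)cc1`, 16700 nM
compound 2 `COc1ccc2nc(-c3ccc(-n4c(C)ccc4-c4ccc(C)cc4)cc3)sc2c1`, 20500 nM
compound 3 `COc1cc2nc(-c3ccc(-n4c(C)ccc4-c4ccc(F)cc4)cc3)sc2c(OC)c1OC`, 13100 nM

All three values sit within the usual scatter of one another, so no order among them is claimed. Within the data shown here, the one counted step, a 1.2-fold higher number from compound 1 to compound 2 (0.09 log units; within the scatter), is methoxy in place of fluoro on an aromatic carbon. The difference between the core of compound 1 and the core of compound 3 is not broken down here.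

Compound 4 `COc1ccc(-c2ccc(C)n2-c2ccc(-c3nc4cc(OC)c(OC)c(OC)c4s3)cc2)cc1` is not yet measured. It differs from compound 3 by methoxy in place of fluoro on an aromatic carbon. This is the same kind of change as from compound 1 to compound 2, not the same: there the place was part of a fused or bridged system of two rings, meta to a fused ring and para to a fused ring; here it is on a six-membered aromatic ring of carbon only, para to a large group. Given that the earlier step, a 1.2-fold higher number from compound 1 to compound 2 (0.09 log units; within the scatter), stayed within the scatter, a step of similar size, a 1.1-fold higher number from compound 3 to compound 4 (0.06 log units; within the scatter), is expected. Compound 4 is estimated at 15000 nM in this assay, between 7000 nM and 32000 nM.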

Compound 4, half-maximal inhibitory concentration: 12500 nM
Compound 4: the middle estimate sits 1.2-fold (0.08 log units) above what was measured, within the range that was stated.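

In this assay, methoxy in place of fluoro on the aromatic carbon para to a large group gives a 1.0-fold lower number from compound 3 to compound 4 (0.02 log units; within the scatter). Set beside the earlier swap, the change reads alike on both cores: the same change on two cores in this assay, a 1.2-fold higher number (0.09 log units; within the scatter) from compound 1 to compound 2 and a 1.0-fold lower number (0.02 log units; within the scatter) from compound 3 to compound 4, 1.3-fold (0.11 log units) apart, within the scatter of two such steps. Among these compounds, this shows only that the swap left the number within the scatter in these two pairs; it does not show that the change transfers generally, since the swap sits at a different place in each pair and neither step is large enough to reveal any dependence on the core.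

The compounds shown leave open whether an amine, a carboxylic acid or a longer chain in place of the methoxy of the 4-methoxyphenyl group would move the number beyond the scatter. From the compounds shown here alone, whether the swap behaves the same way on any further core also remains open.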